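Swapping the thiazolylethenyl arm of compound 1 for acetylphenyl

The source may report more compounds than this note shows. Statements on the series, on what has been measured and on what is new or still open speak of the compounds shown alone.

Measured compounds:
- compound 1, `COC(=O)/C=C/c1cccc(N(Cc2ccc(/C=C/c3scnc3C)cc2)C(=O)C2CCCCC2)c1`: 227 nM
- compound 2, `COC(=O)/C=C/c1cccc(N(Cc2ccc(/C=C/c3scnc3C)cc2)C(=O)C(C)C)c1`: 228 nM
- compound 3, `COC(=O)/C=C/c1cccc(N(Cc2ccc(/C=C/C(=O)OC(C)(C)C)cc2OCc2ccccc2)C(=O)C2CCCCC2)c1`: this compound reached only a limit in the assay

The series was examined in an assay on isolated protein with Bile acid receptor (Homo sapiens) as the target; a lower number here means that less compound is needed, a higher number that more compound is needed for the effect. Compound 1 stands as the lowest of the two numbers obtained, but its nearest neighbour is within the scatter: the step of a 1.0-fold higher number from compound 1 to compound 2 (0.00 log units; within the scatter) shows that isopropyl in place of cyclohexyl on the carbonyl carbon leaves the number essentially unchanged. Compound 3 gave > 1000 nM, which is a limit of this assay and not a number; this is the situation described by the limit of > 1000 nM in this assay, at which 1 of the 3 values shown sits.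

Compound 4, `COC(=O)/C=C/c1cccc(N(Cc2ccc(-c3cccc(C(C)=O)c3)cc2)C(=O)C2CCCCC2)c1`, is not yet measured. Its change from compound 1 is 3-acetylphenyl in place of 2-(4-methyl-1,3-thiazol-5-yl)ethenyl on an aromatic carbon. Among the compounds with values here, no measured step touches this part of the molecule; the only measured step, from compound 1 to compound 2, alters the group on the carbonyl carbon and is flat. Compound 3 differs from compound 1 at two places at once, so it offers no single-step guidance. The outcome in this assay is therefore uncertain, with a modest weakening judged somewhat more likely than an improvement. Compound 4 is expected to give about 400 nM, within a range of 150 nM to 1500 nM, corresponding to an estimated step of a 1.8-fold higher number from compound 1 to compound 4 (0.25 log units; within the scatter).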

Compound 4, half-maximal effective concentration: 227 nM
Compound 4: middle estimate off by 1.8-fold (0.25 log units), on the high side; the range from low to high includes it.
By their numbers in this assay, from the lowest: compounds 1, 4 and 2 (each within the scatter of the next). At a limit, above all of these: compound 3.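

Within the data shown here, the result, no change at the digits printed from compound 1 to compound 4 (within the scatter), is the first measured change at this position in this assay, and it shows that 3-acetylphenyl can stand in for 2-(4-methyl-1,3-thiazol-5-yl)ethenyl on the aromatic carbon para to a large group. In this single pair, the five-membered aromatic ring with its nitrogen and sulfur is therefore not needed to hold the number, and a six-membered aromatic ring of carbon only serves as well. Nothing measured here bears on why the two groups match.

The compounds shown leave open whether the acetyl group matters at all, and whether a carboxylic acid or an amine in its place on the phenyl ring would hold the number too. They also leave open whether any group at this position can move the number beyond the scatter.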